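Acetyl on the aromatic nitrogen: notes toward compound 4

This account rests on a few compounds, and the source may have more. Where it says the series, first, only, none or still open, it means among the compounds named here.

Measured so far in a functional assay on M14 cells (Homo sapiens) for cytotoxicity, read by MTT assay, with a stated time of 72 h; a higher number here means a weaker inhibitor, a lower number a stronger inhibitor:
Compound 1, `CC(=O)n1cc(/C=C(/C(=O)O)c2ccc(Cl)cc2)c2cc(OCc3ccccc3)ccc21`: compound 1 gives > 100000 nM, a limit of the assay rather than a number.
Compound 2, `CC(=O)n1cc(/C=C(/C(=O)O)c2ccccc2)c2cc(OCc3ccccc3)ccc21`: compound 2 gives > 100000 nM, likewise a limit.
Compound 3, `COc1ccc(/C(=C\c2c[nH]c3ccc(OCc4ccccc4)cc23)C(=O)O)cc1`: compound 3 gives 58400 nM.

Among the measured compounds shown here, compound 3 thus holds the only number in this assay; the two other values are limits, and nothing can be said about its rank against them. For the measured compounds named here, the one step between measured compounds, a step that the two limits leave unreadable from compound 1 to compound 2, stays unreadable because the limit of > 100000 nM in this assay, at which 2 of the 3 values shown sit, holds both of its ends, and it concerns a hydrogen in place of chloro on an aromatic carbon, not the nitrogen at issue here.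

Compound 4, `COc1ccc(/C(=C\c2cn(C(C)=O)c3ccc(OCc4ccccc4)cc23)C(=O)O)cc1`, differs from compound 3 by acetyl in place of hydrogen on an aromatic nitrogen. Going by the values given here, no measured step touches this nitrogen, so no step fixes the size of the change. What the series does show for compounds carrying acetyl on this nitrogen is the limit of > 100000 nM in this assay, at which 2 of the 3 values shown sit. Compound 4 is therefore expected to come out weaker than compound 3, with a 1.9-fold higher number from compound 3 to compound 4 (0.27 log units; within the scatter) as the expected step in this assay. In this assay compound 4 is expected to give 110000 nM, between 40000 nM and 300000 nM, with a fair chance that only a limit is reported. The measured value follows.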

Compound 4, half-maximal inhibitory concentration: > 100000 nM
Compound 4 gave a limit, no number; the forecaster's own chance of this, stated with the estimate: 55%; the middle value does not contradict the limit.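

Among the compounds shown here, for the first time a step touches this aromatic nitrogen: in this assay, acetyl in place of hydrogen gives an at least 1.7-fold higher number from compound 3 to compound 4 (0.23 log units; that floor lies within the scatter). The earlier compounds shown here could not show this, as both carry acetyl on the nitrogen and neither has a partner with hydrogen there; the pair now shows that, with the methoxy group held constant, the acetyl compound gives only a limit, though the steps to compound 4 from compound 1 and compound 2 cannot be read. Compound 1, compound 2 and compound 4, all with acetyl on this nitrogen, now share a single limit, and no compound shown goes against that: the limit of > 100000 nM in this assay, at which 3 of the 4 values shown sit.

From the compounds shown here alone, the true size of the step remains open, with only its floor readable and that floor within the scatter. Also open, going by these compounds, is whether a methyl group or a longer acyl chain on this nitrogen would give a readable number, and how chloro or hydrogen in place of methoxy would read with hydrogen on the nitrogen.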